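A few compounds are considered here, and "the series" means these few. Any claim that something is new, unique, unknown or untested is made for them only; others in the source may bear on it.

Of the compounds shown here, three sharing one core have been measured in a functional assay on HL-60 cells (Homo sapiens) for antiproliferative activity, with a stated time of 72 h; on this read-out lower numbers stand for stronger inhibition and higher numbers for weaker inhibition. Compound 1 `OC[C@H]1O[C@@H](n2cnc3c(NCc4ccccc4F)ncnc32)[C@H](O)[C@@H]1O` gives 3200 nM, compound 2 `OC[C@H]1O[C@@H](n2cnc3c(NCc4ccc(F)cc4)ncnc32)[C@H](O)[C@@H]1O` gives 1200 nM, and compound 3 `OC[C@H]1O[C@@H](n2cnc3c(NCc4ccc(Br)cc4)ncnc32)[C@H](O)[C@@H]1O` gives 47400 nM. Compound 3 thus carries the highest number of the three and is the weakest inhibitor among them. Compound 4 `Cc1cccc(CNc2ncnc3c2ncn3[C@@H]2O[C@H](CO)[C@@H](O)[C@H]2O)c1` has not yet been measured. It differs from compound 3 by 3-methylphenyl in place of 4-bromophenyl on a saturated chain carbon bound to a nitrogen on an aromatic ring, with 3-methylphenyl in place of 4-bromophenyl on a saturated chain carbon bound to a nitrogen on an aromatic ring.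

Two large steps bear on this change, a 15-fold higher number from compound 1 to compound 3 (1.17 log units; beyond the scatter) and a 40-fold higher number from compound 2 to compound 3 (1.60 log units; beyond the scatter). The two fluorinated compounds stand much closer together, with only a modest 2.7-fold lower number from compound 1 to compound 2 (0.43 log units; beyond the scatter). Among the measured compounds shown here, no measured compound carries 3-methylphenyl, so the comparison is indirect, and compound 4 may not match the fluorinated pair. A large step towards a lower number is nevertheless expected, estimated as a 7.9-fold lower number from compound 3 to compound 4 (0.90 log units; beyond the scatter). Compound 4 is expected at about 6000 nM, with an estimated range of 1200 nM to 30000 nM.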

Compound 4, half-maximal inhibitory concentration: 6400 nM
The estimate for compound 4 lay 1.1-fold (0.03 log units) below the measured number; the measured number falls inside the stated range.
By their numbers in this assay, from the lowest: compound 2; then compounds 1 and 4 (each within the scatter of the next); then compound 3.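

In this assay, replacing 4-bromophenyl with 3-methylphenyl on a saturated chain carbon bound to a nitrogen on an aromatic ring gives a 7.4-fold lower number from compound 3 to compound 4 (0.87 log units; beyond the scatter), so the high number of compound 3 does not extend to this bromine-free group. Compound 4 does not fully match the fluorinated pair: against 4-fluorophenyl the change gives a 5.3-fold higher number from compound 2 to compound 4 (0.73 log units; beyond the scatter), whereas against 2-fluorophenyl it gives a 2.0-fold higher number from compound 1 to compound 4 (0.30 log units; within the scatter). No evidence is available to explain these differences.

The compounds shown cannot separate the change of group from the change of ring position, which 3-bromophenyl and 4-methylphenyl would help to do. As far as these compounds go, how an amine or a carboxylic acid on the phenyl ring, or a longer chain to it, would read here also remains open.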